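The source may report more compounds than this note shows. Statements on the series, on what has been measured and on what is new or still open speak of the compounds shown alone.

In a functional assay on isolated protein for agonist activity at Glucose-dependent insulinotropic receptor (Rattus norvegicus), read by HTRF and cAMP accumulation (on this read-out higher numbers stand for an effect only at larger amounts of compound and lower numbers for an effect already at smaller amounts), compound 1 `CC(C)(C)OC(=O)N1CCC(O[C@H]2CC[C@@H](Oc3ccc(S(C)(=O)=O)cc3)CC2)CC1` gives 1390 nM, while compound 2 `CC(C)OC(=O)N1CCC(O[C@H]2CC[C@H](Oc3ccc(S(C)(=O)=O)nc3)CC2)CC1` gives 201 nM. On these two numbers compound 2 stands lowest; its nearest neighbour is compound 1, whose number is higher by a margin that lies beyond the usual scatter. The step from compound 2 to compound 3 `Cc1nc(S(C)(=O)=O)ccc1O[C@H]1CC[C@H](OC2CCN(C(=O)OC(C)C)CC2)CC1` introduces (methyl in place of hydrogen on an aromatic carbon), a methyl in place of hydrogen on an aromatic carbon. For the measured compounds named here, no pair among the measured compounds shows this change, so there is no measured step to lean on. The methyl is a small addition to a compound that already has the lower number, and the writer expects the number for compound 3 in this assay to move little, with a step from compound 2 to compound 3 of about a 1.2-fold higher number from compound 2 to compound 3 (0.09 log units; within the scatter), within or only just beyond the scatter. Compound 3 is therefore estimated at 250 nM, with a range from 80 nM to 800 nM.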

Compound 3, half-maximal effective concentration: 89 nM
Estimate against measurement, compound 3: 2.8-fold (0.45 log units) above; the measured number falls inside the stated range.
By their numbers in this assay, from the lowest: compound 3; then compound 2; then compound 1.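

In this assay, for the compounds shown here, the methyl in place of hydrogen on an aromatic carbon brings a 2.3-fold lower number from compound 2 to compound 3 (0.35 log units; beyond the scatter) and gives the first single-place step, modest but beyond the scatter. The position next to the ring nitrogen and ortho to a large group therefore takes a methyl, and the number falls rather than rises, which compound 1 and compound 2 could not show because they differ in more than one place. Nothing given here accounts for the direction of this step.

As far as these compounds go, whether an ethyl group, a methoxy group or a chlorine atom at the same position would lower the number further remains open. From the compounds shown here alone, it is also open whether a methyl would give a similar step on the ring of compound 1, which has no ring nitrogen.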